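Methoxy for fluoro on the sulfanyl-linked ring

The source may hold more compounds than are shown below. What is called first, only, known or untested is meant among the compounds shown, and "the series" means these compounds.

Working notes on a small set sharing one core. Compound 1 `Nc1cc(N)c2nc(-c3ccccc3)c(Sc3ccc(F)cc3)nc2c1` in a functional assay on SF-295 cells (Homo sapiens) for inhibition, read by sulforhodamine B assay, with a stated time of 48 h (a higher number here means a weaker inhibitor of growth, a lower number a stronger inhibitor of growth), gives 30200 nM. Compound 2 `COc1ccc(CNc2nc3cc(N)cc(N)c3nc2-c2ccccc2)cc1OC` in this assay gives 28200 nM, which sits within the scatter of the value for compound 1, so the two are indistinguishable. Compound 3 `CCOC(=O)[C@H](CCC(=O)O)NC(=O)c1ccc(CNc2nc3cc(N)cc(N)c3nc2-c2ccccc2)cc1` gives only a limit in this assay, < 100000 nM, not a number (the limit of < 100000 nM in this assay, at which 1 of the 3 values shown sits). For the measured compounds named here, no step between measured compounds with a single change is available, so the size of any step is untested here.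

Compound 4 `COc1ccc(Sc2nc3cc(N)cc(N)c3nc2-c2ccccc2)cc1` differs from compound 1 by methoxy in place of fluoro on an aromatic carbon. Going by the values given here, with no comparable step measured, the expected step of a 1.1-fold lower number from compound 1 to compound 4 (0.05 log units; within the scatter) is taken as none beyond the scatter. Compound 4 is therefore estimated at 27000 nM, between 10000 nM and 75000 nM.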

Compound 4, concentration for total growth inhibition: < 100000 nM
Compound 4: only a limit was reported; the forecaster's own chance of this, stated with the estimate: 15%; the middle value does not contradict the limit.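

For the compounds shown here, compound 4 gives < 100000 nM in this assay and that is a limit, not a number, so no step from compound 1 to compound 4 can be read: the limit of < 100000 nM in this assay, at which 2 of the 4 values shown sit.

From the compounds shown here alone, whether 4-methoxyphenyl in place of 4-fluorophenyl shifts growth inhibition in either direction stays open.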